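Propanoyl in Place of 4-Nitrophenyl: Expected Paw Edema Inhibition

A few compounds are considered here, and "the series" means these few. Any claim that something is new, unique, unknown or untested is made for them only; others in the source may bear on it.

Three compounds sharing one core were tested in a functional assay on the whole organism (strain Wistar) for inhibition, with Rattus norvegicus as the target, read by paw edema, with a stated time of 30 min, at a dose of 50 mg/kg by the oral route; on this read-out lower numbers stand for less inhibition and higher numbers for more inhibition at the one dose given (going by the name of the read-out). Compound 1 `CCC(=O)N1N=C(c2ccc(F)cc2)CC1c1cn(-c2ccccc2)nc1-c1ccc(Cl)c(Cl)c1` gives 51.1%. Compound 2 `O=[N+]([O-])c1ccc(N2N=C(c3ccc(F)cc3)CC2c2cn(-c3ccccc3)nc2-c2ccc(Cl)c(Cl)c2)cc1` gives 45.7%, and compound 3 `O=[N+]([O-])c1ccc(N2N=C(c3ccc(Cl)cc3)CC2c2cn(-c3ccccc3)nc2-c2ccc(Cl)c(Cl)c2)cc1` gives 48.9%. Compound 1 and compound 2 differ by propanoyl in place of 4-nitrophenyl on an amine nitrogen in a ring, and the step of a number 5.4 percentage points higher from compound 2 to compound 1 (within the scatter). The cores of compound 2 and compound 3 differ by chloro in place of fluoro on an aromatic carbon, and the step of a number 3.2 percentage points higher from compound 2 to compound 3 (within the scatter).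

Compound 4 `CCC(=O)N1N=C(c2ccc(Cl)cc2)CC1c1cn(-c2ccccc2)nc1-c1ccc(Cl)c(Cl)c1` has not yet been measured. It differs from compound 3 by propanoyl in place of 4-nitrophenyl on an amine nitrogen in a ring. For the measured compounds named here, this is the same kind of change as the one between compound 2 and compound 1, though around the place the ring atom two ring bonds away bears a 4-chlorophenyl group rather than a 4-fluorophenyl group. Because the earlier change of this kind gave a number 5.4 percentage points higher from compound 2 to compound 1 (within the scatter), a step of about that size, within the scatter, is expected here as well. For compound 4 the expected step is a number 5.1 percentage points higher from compound 3 to compound 4 (within the scatter). Compound 4 is therefore estimated at 54%, likely between 42% and 66%.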

Compound 4, a percentage reported as inhibition, in the whole organism at one dose (the size of the read-out at that dose, not a potency): 47.9%
Beside the measured number, compound 4's estimate is 6.1 percentage points above it; measured number inside the range.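

In this assay, propanoyl in place of 4-nitrophenyl on the amine nitrogen in the ring gives a step of a number 1 percentage points lower from compound 3 to compound 4 (within the scatter), and chloro in place of fluoro on an aromatic carbon gives a step of a number 3.2 percentage points lower from compound 1 to compound 4 (within the scatter). The first change shows no difference between the two cores that stands out from the scatter: the same change on two cores in this assay, a number 5.4 percentage points higher (within the scatter) from compound 2 to compound 1 and a number 1 percentage points lower (within the scatter) from compound 3 to compound 4, 6.4 percentage points apart, within the scatter of two such steps
The data do not establish a direction for either change or show that the two changes would behave alike on other cores, and the second change likewise shows no difference that stands out from the scatter: the same change on two cores in this assay, a number 3.2 percentage points higher (within the scatter) from compound 2 to compound 3 and a number 3.2 percentage points lower (within the scatter) from compound 1 to compound 4, 6.4 percentage points apart, within the scatter of two such steps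

The compounds shown leave open how a longer acyl chain, a benzoyl group or a carboxylic acid on the amine nitrogen in the ring would read out, and what a methoxy group would give in place of chloro or fluoro on the aromatic carbon. They also leave open whether these four compounds would stay as close together at other doses or times.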